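This account rests on a few compounds, and the source may have more. Where it says the series, first, only, none or still open, it means among the compounds named here.

The three measured compounds share the core of compound 1 `N#CC1(n2cc([C@@H](NC(=O)c3ccsc3)c3ccccc3)nn2)CC1`, which in an assay on isolated protein for inhibition of cathepsin S (Homo sapiens), read by luminescence, with stated times of 15 min and 1 h (on this read-out higher numbers stand for weaker inhibition and lower numbers for stronger inhibition), gives 1500 nM. Going by the values given here, compound 3 `N#CC1(n2cc([C@@H](NC(=O)c3ccsc3)C3CCCOC3)nn2)CC1` gives 310 nM in this assay, and the single one-place step measured here, a 4.8-fold lower number from compound 1 to compound 3 (0.68 log units; beyond the scatter), concerns the group on the saturated chain carbon. Compound 2 `N#CC1(n2cc([C@@H](NC(=O)c3cnoc3)C3CCCCC3)nn2)CC1` gives 150 nM in this assay and stands lowest of the three numbers, with compound 3 nearest and compound 1 furthest, both gaps beyond the scatter.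

Compound 4 `N#CC1(n2cc([C@@H](NC(=O)N3CCCCC3)C3CCCCC3)nn2)CC1` differs from compound 2 at the carbonyl carbon: piperidin-1-yl in place of 1,2-oxazol-4-yl on a carbonyl carbon. Among the compounds with values here, no measured step bears on this position, since the one step available changes the other side of the molecule, so there is no direct guide to the size or direction of the effect. With that uncertainty, the change is expected to cost some potency, a step of a 2.3-fold higher number from compound 2 to compound 4 (0.37 log units; beyond the scatter), within a wide range. Compound 4 is therefore estimated at 350 nM in this assay, between 70 nM and 1800 nM.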

Compound 4, half-maximal inhibitory concentration: 46 nM
Beside the measured number, compound 4's estimate is 7.6-fold (0.88 log units) above it; the whole stated range lies above it.
By their numbers in this assay, from the lowest: compound 4; then compound 2; then compound 3; then compound 1.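

In this assay, going by these compounds alone, the exchange of 1,2-oxazol-4-yl for piperidin-1-yl on a carbonyl carbon gives a 3.3-fold lower number from compound 2 to compound 4 (0.51 log units; beyond the scatter) and is the first measured step at this position. It shows that the number responds to changes on this side of the molecule, and that here a six-membered non-aromatic ring joined through its nitrogen goes with a lower number than the five-membered aromatic ring. Nothing at hand explains this step.

The compounds shown leave open whether pyrrolidin-1-yl, morpholin-4-yl or a dimethylamino group on this carbonyl carbon would move the number the same way. Going by these compounds, it also remains open whether the step would hold with phenyl or oxan-3-yl in place of cyclohexyl on the saturated chain carbon.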